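The source may report more compounds than this note shows. Statements on the series, on what has been measured and on what is new or still open speak of the compounds shown alone.

Working notes on the series. In a functional assay on A549 cells (Homo sapiens) for cytotoxicity, read by MTT assay, with a stated time of 72 h (a lower number here means a stronger inhibitor, a higher number a weaker inhibitor), compound 1 `Cc1cc(=O)n(-c2cccc(F)c2)nc1C(=O)Nc1ccc(Oc2ncnc3[nH]ccc23)c(F)c1` gives 31500 nM. Compound 2 `Cc1ccc(-n2nc(C(=O)Nc3ccc(Oc4ncnc5[nH]ccc45)c(F)c3)c(C)cc2=O)cc1` carries the change (4-methylphenyl in place of 3-fluorophenyl on an aromatic nitrogen), and in this assay compound 2 gives 18500 nM; the step is a 1.7-fold lower number from compound 1 to compound 2 (0.23 log units; within the scatter). Compound 3 `Cc1cc(=O)n(-c2cccc(F)c2)nc1C(=O)Nc1ccc(Oc2ncnc3c2ccn3C)c(F)c1` differs from compound 1 in its core by methyl in place of hydrogen on an aromatic nitrogen. For compound 3 in this assay only a limit is recorded, > 60000 nM. The step of an at least 1.9-fold higher number from compound 1 to compound 3 (0.27 log units; that floor lies within the scatter) is therefore a floor rather than a number; compound 3 is the case described by the limit of > 60000 nM in this assay, at which 1 of the 3 values shown sits. Compound 4 `Cc1ccc(-n2nc(C(=O)Nc3ccc(Oc4ncnc5c4ccn5C)c(F)c3)c(C)cc2=O)cc1` is not yet measured and stands to compound 3 as compound 2 stands to compound 1, the change being (4-methylphenyl in place of 3-fluorophenyl on an aromatic nitrogen), at the same place in both pairs. The expected step here is a step that the limit leaves unreadable from compound 3 to compound 4, resting on the earlier step of a 1.7-fold lower number from compound 1 to compound 2 (0.23 log units; within the scatter) that stayed within the scatter. Starting from a value that is itself a limit, compound 4 is expected to sit near or beyond that same limit in this assay, with an estimate of 70000 nM. The expected range for compound 4 runs from 30000 nM to 160000 nM.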

Compound 4, half-maximal inhibitory concentration: > 60000 nM
Compound 4: only a limit was reported; the forecaster's own chance of this, stated with the estimate: 60%; the middle value does not contradict the limit.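

In this assay compound 4 is recorded only as a limit, > 60000 nM, and with compound 3 also a limit, the step between them cannot be read, so nothing shows whether the 4-methylphenyl for 3-fluorophenyl change carries over to the core of compound 3. Methyl in place of hydrogen on the aromatic nitrogen gives an at least 3.2-fold higher number from compound 2 to compound 4 (0.51 log units; beyond the scatter), a step beyond the scatter on the 4-methylphenyl pair, while the same change on the 3-fluorophenyl pair has a floor within the scatter, so the two pairs agree in not contradicting a rise but only the 4-methylphenyl pair establishes one. The size of this step is not shown to carry from one pair to the other: the same change on two cores in this assay, an at least 1.9-fold higher number (0.27 log units; that floor lies within the scatter) from compound 1 to compound 3 and an at least 3.2-fold higher number (0.51 log units; beyond the scatter) from compound 2 to compound 4; the limit leaves it open whether they differ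

Going by these compounds, how far compound 3 and compound 4 lie past the limit stays open. Also open, on these data alone, is whether an ethyl group or a longer chain on that aromatic nitrogen, or an amine or a carboxylic acid on the phenyl ring, would give a readable value in this assay.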